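The source may hold more compounds than are shown below. What is called first, only, known or untested is meant among the compounds shown, and "the series" means these compounds.

Compound 1 `CCCCOC(=O)CNC(=O)[C@H](CSc1ccc([N+](=O)[O-])cc1[N+](=O)[O-])NC(=O)CC[C@H](NC(=O)CC(C)(C)C)C(=O)OCCCC` gives 250 uM in a toxicity assay on KB cells (Homo sapiens) for cytotoxicity, read by fluorescence, with a stated time of 3 days; a higher number here means that more compound is needed for the effect, a lower number that less compound is needed.
Compound 2 `CCCCOC(=O)CNC(=O)[C@H](CSc1ccc([N+](=O)[O-])cc1[N+](=O)[O-])NC(=O)CC[C@H](N)C(=O)OCCCC` gives 107 uM in this assay.
Compound 3 `CCCCOC(=O)CNC(=O)[C@H](CSc1ccc([N+](=O)[O-])cc1[N+](=O)[O-])NC(=O)CC[C@H](Nc1ccc([N+](=O)[O-])cc1[N+](=O)[O-])C(=O)OCCCC` reaches only a limit, > 300 uM, in this assay.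

Compound 3 therefore stands at the edge of what this assay reports, (the limit of > 300 uM in this assay, at which 1 of the 3 values shown sits), and the two other compounds sit below it. The structure not yet measured is compound 4 `CCCCOC(=O)CNC(=O)[C@H](CSc1ccc([N+](=O)[O-])cc1[N+](=O)[O-])NC(=O)CC[C@H](NC(=O)OC(C)(C)C)C(=O)OCCCC`, which differs from compound 3 in one place: tert-butoxycarbonyl in place of 2,4-dinitrophenyl on an amine nitrogen. Among the compounds with values here, two measured steps bear on this position. From compound 2 to compound 3 the number rose, an at least 2.8-fold higher number from compound 2 to compound 3 (0.44 log units; beyond the scatter), while from compound 1 to compound 3 it moved little, an at least 1.2-fold higher number from compound 1 to compound 3 (0.07 log units; that floor lies within the scatter). Compound 1, which carries neopentylcarbonyl on that nitrogen, is the closest measured relative of the tert-butoxycarbonyl compound 4. In this assay compound 1 gives 250 uM. Compound 4 is therefore expected to come out near compound 1, which would mean a step of an at least 1.3-fold lower number from compound 3 to compound 4 (0.13 log units; that floor lies within the scatter), though a result at the limit again cannot be excluded. The estimate for compound 4 in this assay is 220 uM, between 110 uM and 400 uM.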

Compound 4, concentration for half-maximal effect: 70.4 uM
For compound 4 the middle estimate is 3.1-fold (0.49 log units) above the measured one; the measured number lies below the stated range.
By their numbers in this assay, from the lowest: compounds 4 and 2 (each within the scatter of the next); then compound 1. At a limit, above all of these: compound 3.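

Tert-butoxycarbonyl in place of 2,4-dinitrophenyl on the amine nitrogen gives an at least 4.2-fold lower number from compound 3 to compound 4 (0.62 log units; beyond the scatter) in this assay, and this step rests on a limit for compound 3: the limit of > 300 uM in this assay, at which 1 of the 4 values shown sits.

Tert-butoxycarbonyl in place of hydrogen on that nitrogen stays within the scatter, at a 1.5-fold lower number from compound 2 to compound 4 (0.18 log units; within the scatter). The sharpest new finding lies in the change from neopentyl to tert-butoxy on the carbonyl carbon, a 3.6-fold lower number from compound 1 to compound 4 (0.55 log units; beyond the scatter), which shows that two groups joined to this nitrogen through a carbonyl do not read alike.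

On these data alone, whether a methoxycarbonyl or an acetyl group on the same nitrogen would fall with compound 4 or with compound 1 remains open. Also open, as far as these compounds go, is whether these steps would hold with a carboxylic acid in place of the butyl esters.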